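Methyl in place of fluoro on compound 3

A few compounds are considered here, and "the series" means these few. Any claim that something is new, unique, unknown or untested is made for them only; others in the source may bear on it.

In a functional assay on A549 cells (Homo sapiens) for antiproliferative activity, read by MTT assay, with a stated time of 72 h (a lower number here means a stronger inhibitor, a higher number a weaker inhibitor), compound 1 `COc1ccc(/C=C/C(=O)/C=C/c2nc(C)c(C)nc2C)cc1` gives 3500 nM and compound 2 `COc1ccc(/C=C/C(=O)/C=C/c2nc(C)c(C)nc2C)cc1OC` gives 3790 nM while compound 3 `Cc1nc(C)c(/C=C/C(=O)/C=C/c2ccc(F)cc2)nc1C` gives 5900 nM and so stands within the scatter of both. Compound 4 `Cc1ccc(/C=C/C(=O)/C=C/c2nc(C)c(C)nc2C)cc1` differs from compound 3 by methyl in place of fluoro on an aromatic carbon. The closest measured change, fluoro in place of methoxy on an aromatic carbon (a 1.7-fold higher number from compound 1 to compound 3 (0.23 log units; within the scatter)), lies within the scatter, as does methoxy in place of hydrogen (a 1.1-fold higher number from compound 1 to compound 2 (0.03 log units; within the scatter)). No step beyond the scatter is therefore expected in this assay, and the estimate is a 1.5-fold lower number from compound 3 to compound 4 (0.17 log units; within the scatter) for this change. Compound 4 is expected at 4000 nM (estimated range 1800 nM to 8500 nM).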

Compound 4, half-maximal inhibitory concentration: 4300 nM
Compound 4: the middle estimate sits 1.1-fold (0.03 log units) below what was measured; the measured number falls inside the stated range.
By their numbers in this assay, from the lowest: compounds 1, 2, 4 and 3 (each within the scatter of the next).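

In this assay, the change from 4-fluorophenyl to 4-methylphenyl gives a 1.4-fold lower number from compound 3 to compound 4 (0.14 log units; within the scatter), and methyl in place of methoxy gives a 1.2-fold higher number from compound 1 to compound 4 (0.09 log units; within the scatter). Both steps lie within the scatter, so methoxy, fluoro and methyl on this aromatic carbon, para to a large group, cannot be told apart in this read-out. No available evidence bears on this result.

On these data alone, whether an amine or a carboxylic acid at this place would give a step beyond the scatter remains open. So does the effect of any change to the shared core.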